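The source may report more compounds than this note shows. Statements on the series, on what has been measured and on what is new or still open speak of the compounds shown alone.

In a functional assay on MCF7 cells (Homo sapiens) for inhibition (a higher number here means a weaker inhibitor of growth, a lower number a stronger inhibitor of growth), the three measured compounds stand as follows:

Compound 1 `C=C1CCCC(C)(C)C1(O)CC/C(C)=C/CC[C@]1(C)CC[C@@H]([C@@H](C)C(=O)OC)OO1` gives > 17500 nM, a limit of the assay.
Compound 2 `C=C1CCC[C@H]2[C@](C)(CC[C@]3(C)CC[C@H]([C@@H](C)C(=O)O)OO3)[C@@H](C)CC[C@]12C` gives 1780 nM.
Compound 3 `C=C1CCCC(C)(C)C1CC[C@@]1(C)CC[C@H]([C@@H](C)C(=O)O)OO1` gives > 12500 nM, again a limit of the assay.

Compound 3 therefore sits at the limit of > 12500 nM in this assay, at which 1 of the 3 values shown sits, while compound 1 sits at the limit of > 17500 nM in this assay, at which 1 of the 3 values shown sits; only compound 2 returns a number. Compound 4 `C=C1CCCC(C)(C)C1CC[C@]1(C)CC[C@@H]([C@@H](C)C(=O)O)OO1` keeps every atom and bond of compound 3 and differs only in how two ring carbons are drawn: the two compounds have the same atoms and bonds; at least one stereo element is drawn with a configuration in one of them and without one in the other: 2 of 4 stereo elements differ; a stereocentre at a saturated ring carbon is drawn S in compound 3 and R in compound 4; a stereocentre at a saturated ring carbon is drawn R in compound 3 and S in compound 4. Among the compounds with values here, no measured pair shows what such a change does in this assay, so the direction is open; a swap of two stereocentres could move the value in either direction, or not at all beyond the scatter. Compound 4 is expected to give about 9000 nM, between 2500 nM and 30000 nM, a step of an at least 1.3-fold lower number from compound 3 to compound 4 (0.14 log units; that floor lies within the scatter) that is only an estimate.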

Compound 4, concentration for 50% growth inhibition: > 10000 nM
Compound 4: no number, only a limit; the forecaster's own chance of this, stated with the estimate: 45%; middle value at least 1.1-fold (0.04 log units) away from the limit.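

In this assay, within the data shown here, compound 3 and compound 4 each return only a limit, not a number, so no step between them can be read. The compounds shown leave open whether swapping the two ring stereocentres changes growth inhibition at all, and in which direction.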